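This account rests on a few compounds, and the source may have more. Where it says the series, first, only, none or still open, it means among the compounds named here.

Measured compounds:
compound 1 `CCNC(=O)N1CCN(C(=S)SCc2cn(Cc3ccc(Cl)cc3)nn2)CC1` — 35400 nM
compound 2 `Cc1ccc(Cn2cc(CSC(=S)N3CCN(C(N)=O)CC3)nn2)cc1` — 29900 nM

In a functional assay on MGC-803 cells (Homo sapiens) for cytotoxicity, read by MTT assay, with a stated time of 72 h (on this read-out lower numbers stand for stronger inhibition and higher numbers for weaker inhibition), compound 1 gives 35400 nM. In this assay compound 2 gives 29900 nM. The two numbers sit within the usual scatter of each other, so neither compound 1 nor compound 2 can be called the stronger or the weaker of the pair; both sit at a weak level of cytotoxicity against these cells.

The step under consideration leads from compound 2 to compound 3 `CCNC(=O)N1CCN(C(=S)SCc2cn(Cc3ccc(C)cc3)nn2)CC1`. The change is ethyl in place of hydrogen on an amide-type nitrogen. Compound 1 already carries an ethyl group on the same amide-type nitrogen, though it differs from compound 3 in another part of the molecule as well, so no clean comparison of this single change is available among the measured pair. What the two measured values show is that a compound with the ethylcarbamoyl group and a compound with the plain carbamoyl group land at about the same place. The expectation for this step in this assay is therefore no change beyond the scatter, in either direction. Compound 3 is estimated at 31000 nM, with a range from 12000 nM to 80000 nM, which corresponds to an expected step of a 1.0-fold higher number from compound 2 to compound 3 (0.02 log units; within the scatter).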

Compound 3, half-maximal inhibitory concentration: 19800 nM
Compound 3: the middle estimate sits 1.6-fold (0.19 log units) above what was measured; the range from low to high includes it.
By their numbers in this assay, from the lowest: compounds 3, 2 and 1 (each within the scatter of the next).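

In this assay the swap of ethyl for hydrogen on the amide-type nitrogen can now be read on its own, as a single change between two otherwise identical molecules, and it gives a 1.5-fold lower number from compound 2 to compound 3 (0.18 log units; within the scatter) and so does not separate the carbamoyl group from the ethylcarbamoyl group at this place. The same holds for the aromatic carbon, where methyl in place of chloro gives a 1.8-fold lower number from compound 1 to compound 3 (0.25 log units; within the scatter) as the second single change, so neither of the two places has yet shown a difference larger than repeated measurements of one compound would give. No independent measurement accompanies these numbers to say what lies behind them.

Still open, as far as these compounds go, is whether a longer chain on the amide-type nitrogen, such as butyl, or a group carrying an amine or a carboxylic acid there, would take the number beyond the scatter. Equally open, from the compounds shown here alone, is whether methoxy or trifluoromethyl in place of methyl on the aromatic carbon would do so, which would show whether either place matters at all for this cytotoxicity.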